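The compounds below may be only part of what the source reports. "The series", "measured", "known", "first", "only" and "open" are said of these compounds alone.

Working notes on the series. In an assay on isolated protein for inhibition of aldehyde dehydrogenase 1A1 (Homo sapiens), read by spectrophotometry, tested at 10 uM (on this read-out lower numbers stand for less inhibition and higher numbers for more inhibition at the one concentration tested (going by the name of the read-out)), compound 1 `O=C(C1CC1)N1CCN(Cc2nc3ccccc3n2Cc2ccc(F)cc2)CC1` gives 32.7% and compound 2 `O=C(C1CC1)N1CCN(Cc2nc3ccccc3n2CC2CC2)CC1` gives 21.2%, which is the lower of the two numbers recorded so far. Among the compounds with values here, the one measured step, a number 11.5 percentage points lower from compound 1 to compound 2 (beyond the scatter), is the only one bearing on the next change. Compound 3 `O=C(C1CC1)N1CCN(Cc2nc3ccccc3n2Cc2cccc(Cl)c2)CC1` differs from compound 2 as follows: 3-chlorophenyl in place of cyclopropyl on a saturated chain carbon bound to an aromatic nitrogen. The change runs back toward an aryl group on the same carbon, so a step in this assay of about the same size as the first step, in the opposite direction, is expected: a number 11.8 percentage points higher from compound 2 to compound 3 (beyond the scatter). Compound 3 is therefore estimated at 33%, expected to lie between 18% and 48%.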

Compound 3, a percentage reported as inhibition, at one concentration (the size of the read-out at that concentration, not a potency): 71.6%
Beside the measured number, compound 3's estimate is 38.6 percentage points below it; the whole stated range lies below it.
By their numbers in this assay, from the lowest: compound 2; then compound 1; then compound 3.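

In this assay, an aryl group on this saturated chain carbon does not by itself set the number: a number 50.4 percentage points higher from compound 2 to compound 3 (beyond the scatter), but also a number 38.9 percentage points higher from compound 1 to compound 3 (beyond the scatter), so exchanging one aryl group for another matters here as well. Of the three compounds, compound 3, with 3-chlorophenyl, gives the highest number. No evidence at hand explains this gain.

Because 4-fluorophenyl and 3-chlorophenyl differ in both halogen and ring placement, the contribution of each remains unresolved. Going by these compounds, it is also open how 4-chlorophenyl or an amine-bearing chain would read at this carbon.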